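This account rests on a few compounds, and the source may have more. Where it says the series, first, only, none or still open, it means among the compounds named here.

Measured compounds:
- compound 1, `NS(=O)(=O)c1ccc(Nc2nc(N/N=C/c3ccc(C(F)(F)F)cc3)nc(Nc3ccccc3)n2)cc1`, gives 52000 nM in a functional assay on HCT-15 cells (Homo sapiens) for inhibition, read by sulforhodamine B assay, with a stated time of 48 h; a lower number here means that less compound is tolerated, a higher number that more compound is tolerated.
- compound 2, `Cc1nn(-c2ccccc2)cc1/C=N/Nc1nc(Nc2ccccc2)nc(Nc2ccc(S(N)(=O)=O)cc2)n1`, gives > 100000 nM in this assay; this is a limit of the assay, not a number.

Compound 2 therefore stands at the limit of > 100000 nM in this assay, at which 1 of the 2 values shown sits, and only compound 1 carries a number in this assay. Going by the values given here, the one step measured so far, an at least 1.9-fold higher number from compound 1 to compound 2 (0.28 log units; that floor lies within the scatter), has its floor within the scatter, so the two compounds cannot be ordered on what is known.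

Compound 3, `NS(=O)(=O)c1ccc(Nc2nc(N/N=C/c3ccccn3)nc(Nc3ccccc3)n2)cc1`, is the next variation of the shared core: pyridin-2-yl in place of 3-methyl-1-phenyl-1H-pyrazol-4-yl on a carbon with a double bond to nitrogen. Among the compounds with values here, the only step bearing on it is the one from compound 1 to compound 2, which exchanged the aryl on the same carbon and moved the value from a number to the limit. That change in the aryl did not take the number far in either direction beyond the scatter. For compound 3 the step of an at least 1.4-fold lower number from compound 2 to compound 3 (0.15 log units; that floor lies within the scatter) is expected to be small, if anything toward a lower number, and a value near the limit remains likely.

Compound 3 is estimated at 70000 nM in this assay, with a range from 30000 nM to 200000 nM.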

Compound 3, concentration lethal to 50% of the cells: > 100000 nM
Compound 3 ended at the assay's limit (the forecaster's own chance of this, stated with the estimate: 55%); middle value at least 1.4-fold (0.15 log units) from the limit.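

In this assay compound 3 gives > 100000 nM, which is a limit of the assay and not a number. On the carbon with a double bond to nitrogen, the pyridin-2-yl reaches the same limit as the larger 3-methyl-1-phenyl-1H-pyrazol-4-yl, so the step between those two cannot be read, and the exchange of 4-(trifluoromethyl)phenyl for pyridin-2-yl gives an at least 1.9-fold higher number from compound 1 to compound 3 (0.28 log units; that floor lies within the scatter), which again leaves that pair unordered. Two quite different groups at this place now end at the same limit, and the series so far gathers there rather than spreading out: the limit of > 100000 nM in this assay, at which 2 of the 3 values shown sit.

Going by these compounds alone, no step at this position is yet printed beyond the scatter, so whether the group on this carbon moves the number at all in this assay remains open. A pyridin-3-yl, a 4-hydroxyphenyl or a simple butyl chain on the same carbon could show whether any replacement brings a value clearly under the limit and gives steps that can be read.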